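The source may hold more compounds than are shown below. What is called first, only, known or untested is meant among the compounds shown, and "the series" means these compounds.

Measured compounds:
- Compound 1, `CCOC(=O)/C=C(C)/C=C/CC(C)CCCC(C)(C)C`; in a physicochemical assay for lipophilicity (on this read-out higher numbers stand for higher lipophilicity and lower numbers for lower lipophilicity), compound 1 gives 7.15
- Compound 2, `CCOC(=O)/C=C(C)/C=C/CC(C)CCCC(C)CC`; in this assay compound 2 gives 7.81

Within the data shown here, compound 1 holds the lower of the two numbers in this assay; the only neighbour is compound 2, reached by the step of a number 0.66 log units higher from compound 1 to compound 2 (beyond the scatter), which exchanges sec-butyl for tert-butyl on a saturated chain carbon, five bonds along the chain from a double-bonded chain carbon.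

Compound 3, `CC(/C=C/CC(C)CCCC(C)(C)C)=C\C(=O)OC(C)C`, is not yet measured. It differs from compound 1 by methyl in place of hydrogen on a saturated chain carbon bound to an oxygen next to a carbonyl group and a saturated chain carbon. The same difference, cut one bond further out, reads ethoxycarbonyl to isopropoxycarbonyl.

Among the measured compounds shown here, the one measured step sits on the far end of the saturated chain and moves a branch without adding a carbon, so it does not cover the change to compound 3 directly. It shows only that a single alteration on a saturated carbon of this scaffold shifts the read-out by a modest amount that is beyond the scatter. The change to compound 3 adds one carbon at the ester end; an increase in this assay is expected, likely smaller than the step from compound 1 to compound 2, as a number 0.40 log units higher from compound 1 to compound 3 (beyond the scatter). Compound 3 is estimated at 7.55, within 7.2 to 7.9.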

Compound 3, partition coefficient: 7.56
Compound 3: middle estimate off by 0.01 log units, on the low side, within the range that was stated.
By their numbers in this assay, from the lowest: compound 1; then compounds 3 and 2 (each within the scatter of the next).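

Swapping ethoxycarbonyl for isopropoxycarbonyl gives the first reading at this position, and in this assay the added methyl on the saturated chain carbon bound to the oxygen produces a number 0.41 log units higher from compound 1 to compound 3 (beyond the scatter). The earlier step, a number 0.66 log units higher from compound 1 to compound 2 (beyond the scatter), exchanged sec-butyl for tert-butyl elsewhere in the molecule, so it said nothing about this position; the series now has two separate sites at which one change on a saturated carbon moves the read-out beyond the scatter, both upward from compound 1 and both modest. No independent measurement bears on why this methyl produces a step of this size, so the result stands as an observation without an explanation.

This is a single pair, so it does not establish how the read-out would respond to further carbons here, such as a tert-butoxycarbonyl group or a longer chain on the oxygen, or to a free carboxylic acid in place of the ester. Going by these compounds, it is also open whether the same methyl would produce a similar step on compound 2, which carries the sec-butyl group, or whether the two changes would not simply add.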